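Thiazole to thiadiazole on the sulfonamide nitrogen

This account rests on a few compounds, and the source may have more. Where it says the series, first, only, none or still open, it means among the compounds named here.

Measured in a functional assay on RAW264.7 cells (Mus musculus) for inhibition; a higher number here means a weaker inhibitor, a lower number a stronger inhibitor:
- compound 1 `CCOC(=O)C1=CCCCC1S(=O)(=O)Nc1ccc(Cl)cc1`: 400 nM
- compound 2 `CCOC(=O)C1=CCCCC1S(=O)(=O)Nc1nccs1`: > 10000 nM

Compound 2 stands at the limit of > 10000 nM in this assay, at which 1 of the 2 values shown sits. Its value is a limit of the assay and not a number, so any step from it can be sized only loosely.

Compound 3 `CCOC(=O)C1=CCCCC1S(=O)(=O)Nc1nncs1` is still to be measured. It carries 1,3,4-thiadiazol-2-yl in place of 1,3-thiazol-2-yl on a sulfonamide nitrogen.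

Among the measured compounds shown here, only one measured step bears on this change. That step, an at least 25-fold higher number from compound 1 to compound 2 (1.39 log units; beyond the scatter), is large and beyond the scatter, and it put 1,3-thiazol-2-yl in place of 4-chlorophenyl at the same place. The change to compound 3 is narrower, since one five-membered aromatic ring replaces another. No step beyond the scatter is therefore expected in this assay, and a second limit is the likeliest outcome.

The estimated step is a number no higher from compound 2 to compound 3 (the limit leaves the size open). For compound 3 the expected value is 10000 nM, with an estimated range of 3000 nM to 30000 nM.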

Compound 3, half-maximal inhibitory concentration: > 10000 nM
Compound 3: a limit, no number; the forecaster's own chance of this, stated with the estimate: 80%; the middle value lies on the limit itself.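

In this assay compound 3 gives > 10000 nM, which is a limit of the assay and not a number. With 1,3,4-thiadiazol-2-yl on the sulfonamide nitrogen, the comparison with the 4-chlorophenyl group shows an at least 25-fold higher number from compound 1 to compound 3 (1.39 log units; beyond the scatter), so a large loss now holds for both five-membered aromatic rings shown, the one with 2 hetero atoms and the one with 3, and neither compound 2 nor compound 3 goes against it. The step from compound 2 to compound 3 itself cannot be read, because both values stand at one limit: the limit of > 10000 nM in this assay, at which 2 of the 3 values shown sit.

On these data alone, whether the added ring nitrogen of compound 3 changes inhibition at all stays open, since any difference between the two rings would lie beyond the range that this assay reports here. Also open, as far as these compounds go, is which part of the 4-chlorophenyl group supports the value of compound 1, 400 nM, and whether an unsubstituted phenyl, a 4-methoxyphenyl or a pyridin-2-yl group on the sulfonamide nitrogen would stay close to compound 1.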